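The source may report more compounds than this note shows. Statements on the series, on what has been measured and on what is new or still open speak of the compounds shown alone.

Compounds measured so far:
- compound 1 `O=C(CCCCC[C@H](NC(=O)c1cc2ccccc2[nH]1)C(=O)NCc1ccccc1)NO` gives 1260 nM in a functional assay on NFF cells (Homo sapiens) for antiproliferative activity; on this read-out higher numbers stand for weaker inhibition and lower numbers for stronger inhibition
- compound 2 `O=C(Cc1c[nH]c2ccccc12)C[C@@H](Cc1ccccc1)C(=O)N[C@@H](CCCCCC(=O)NO)C(=O)NCc1ccccc1` gives 9800 nM in this assay

Both compounds share a hydroxamic acid chain and a benzylamide, and differ in the group capping the amide nitrogen. Of the two numbers, compound 1 stands lowest, the stronger inhibitor of the pair; compound 2 gives a number well beyond the scatter above it.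

Compound 3 `O=C(/C=C/c1c[nH]c2ccccc12)N[C@@H](CCCCCC(=O)NO)C(=O)NCc1ccccc1` has not yet been measured. It keeps the whole of compound 1 apart from one change: 2-(1H-indol-3-yl)ethenyl in place of 1H-indol-2-yl on a carbonyl carbon. The indole is kept, but is now joined to the carbonyl through a two-carbon bridge holding a double bond, so the cap reaches a little further out.

Within the data shown here, no measured pair shows such a step, so its effect is uncertain. Since the cap stays an indole of similar size, compound 3 is expected to land close to compound 1, with a step of a 1.3-fold higher number from compound 1 to compound 3 (0.10 log units; within the scatter) that is near the edge of the scatter. Compound 3 is estimated at 1600 nM, within a range of 500 nM to 5000 nM.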

Compound 3, half-maximal inhibitory concentration: 10400 nM
Estimate against measurement, compound 3: 6.5-fold (0.81 log units) below, outside the stated range (above it).
By their numbers in this assay, from the lowest: compound 1; then compounds 2 and 3 (each within the scatter of the next).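

In this assay, the group on this carbonyl carbon proves sensitive to change: replacing 1H-indol-2-yl with 2-(1H-indol-3-yl)ethenyl gives an 8.3-fold higher number from compound 1 to compound 3 (0.92 log units; beyond the scatter) and so weaker inhibition. Keeping an indole in this place is therefore not enough on its own to retain the activity of compound 1. The swap moves the point of attachment on the indole and also adds an ethenyl bridge with its double bond, and no supporting evidence explains the rise in the number.

These two changes cannot be separated here: 1H-indol-3-yl attached directly to the carbonyl carbon, or 2-(1H-indol-2-yl)ethenyl, would each carry only one of them. From the compounds shown here alone, how a plain phenyl ring or a saturated two-carbon chain would behave at this place also remains open.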